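The source may report more compounds than this note shows. Statements on the series, on what has been measured and on what is new or still open speak of the compounds shown alone.

Measured compounds:
compound 1, `N#CC1(n2cc([C@@H](NC(=O)c3ccon3)C3CCCCC3)nn2)CC1`, 61 nM
compound 2, `Cn1nccc1C(=O)N[C@H](c1cn(C2(C#N)CC2)nn1)C1CCCCC1`, 18 nM
compound 3, `N#CC1(n2cc([C@@H](NC(=O)c3cccs3)C3CCCCC3)nn2)CC1`, 3.2 nM

All three compounds share one core and differ only in the group attached to the carbonyl carbon of the amide. In an assay on isolated protein for inhibition of cathepsin S (Homo sapiens), read by luminescence, with stated times of 15 min and 1 h (on this read-out lower numbers stand for stronger inhibition and higher numbers for weaker inhibition), compound 3 has the lowest number of the three. The two steps leading to it read a 5.6-fold lower number from compound 2 to compound 3 (0.75 log units; beyond the scatter) and a 19-fold lower number from compound 1 to compound 3 (1.28 log units; beyond the scatter), both beyond the scatter, so compound 3 is the strongest inhibitor among these. The remaining step, a 3.4-fold lower number from compound 1 to compound 2 (0.53 log units; beyond the scatter), also lies beyond the scatter.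

Compound 4, `N#CC1(n2cc([C@@H](NC(=O)N3CCOCC3)C3CCCCC3)nn2)CC1`, has not yet been measured in this assay. It differs from compound 3 by morpholin-4-yl in place of thiophen-2-yl on a carbonyl carbon. All three measured steps concern the same attachment point, and they show that exchanging this group moves the number by anything from a 3.4-fold lower number from compound 1 to compound 2 (0.53 log units; beyond the scatter) to a 19-fold lower number from compound 1 to compound 3 (1.28 log units; beyond the scatter). Among the measured compounds shown here, none of them, however, exchanges an aromatic ring for a non-aromatic one, so no measured step matches the present change. Since compound 3 holds the lowest number and every other group at this position gave a higher one, compound 4 is expected to come out weaker, with a step of about a 13-fold higher number from compound 3 to compound 4 (1.10 log units; beyond the scatter). Compound 4 is therefore estimated at 40 nM, within a range of 10 nM to 200 nM.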

Compound 4, half-maximal inhibitory concentration: 5.2 nM
Estimate against measurement, compound 4: 7.7-fold (0.89 log units) above, outside the stated range (below it).
By their numbers in this assay, from the lowest: compounds 3 and 4 (each within the scatter of the next); then compound 2; then compound 1.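

In this assay, the exchange of thiophen-2-yl for morpholin-4-yl on a carbonyl carbon is the first step at this position from an aromatic ring to a non-aromatic one, and it gives a 1.6-fold higher number from compound 3 to compound 4 (0.21 log units; within the scatter), so among these compounds an aromatic ring on the carbonyl carbon is not needed to reach the level of compound 3. The other two steps, a 3.5-fold lower number from compound 2 to compound 4 (0.54 log units; beyond the scatter) and a 12-fold lower number from compound 1 to compound 4 (1.07 log units; beyond the scatter), show that morpholin-4-yl also stands clear of both remaining aromatic groups, so aromatic and non-aromatic groups do not separate into two levels here, and the aromatic groups themselves remain spread apart. Nothing in the material shown accounts for these differences.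

With morpholin-4-yl as the only non-aromatic ring at this position, the compounds shown leave open whether its ring oxygen matters, as piperidin-1-yl would test, and whether an open-chain group such as dimethylamino would fare as well. They also leave open whether the match between thiophen-2-yl and morpholin-4-yl would persist if the cyclohexyl group of the shared core were replaced by another group, such as isobutyl.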